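This account rests on a few compounds, and the source may have more. Where it says the series, first, only, none or still open, it means among the compounds named here.

Compound 1 `COc1ccc(-c2cnc(NC(=O)C3CCCCC3)n2C)cc1`: in a toxicity assay on THP-1 cells (Homo sapiens) for inhibition (a higher number here means that more compound is tolerated, a lower number that less compound is tolerated), compound 1 gives > 100000 nM, which is a limit of the assay.
Compound 2 `COc1ccc(-c2cnc(NC(=O)CCc3ccccc3)n2C)cc1`: in this assay compound 2 gives > 100000 nM, again a limit.
Compound 3 `COc1ccc(-c2cnc(NC(=O)c3cnc[nH]3)n2C)cc1`: in this assay compound 3 gives > 100000 nM, also a limit.

Compound 3 therefore stands only at a limit, and so do its two neighbours (the limit of > 100000 nM in this assay, at which 3 of the 3 values shown sit). The next compound, compound 4 `COc1ccc(-c2cnc(NC(=O)c3ccccc3C)n2C)cc1`, differs from compound 3 by 2-methylphenyl in place of 1H-imidazol-5-yl on a carbonyl carbon. Among the measured compounds shown here, two measured steps touch the same carbonyl carbon: a step that the two limits leave unreadable from compound 1 to compound 3 and a step that the two limits leave unreadable from compound 2 to compound 3; neither gives a readable size, since both ends sit at the limit. For the measured compounds named here, no measured step therefore shows any movement in this assay on changing this group, and none beyond the scatter is expected here. Compound 4 is expected to remain at the limit as well, estimated at 100000 nM with a range from 30000 nM to 300000 nM, a step of a number no higher from compound 3 to compound 4 (the limit leaves the size open).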

Compound 4, half-maximal cytotoxic concentration: > 100000 nM
Compound 4: no number, only a limit; the forecaster's own chance of this, stated with the estimate: 80%; the middle value sits exactly at the limit.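

Compound 4 sits at a limit, as do compound 1, compound 2 and compound 3, so none of its steps to them can be read: the limit of > 100000 nM in this assay, at which 4 of the 4 values shown sit.

The compounds shown leave open whether any group on the carbonyl carbon changes the half-maximal cytotoxic concentration in this assay.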